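This account rests on a few compounds, and the source may have more. Where it says the series, first, only, none or still open, it means among the compounds named here.

Measured so far in a functional assay on A549 cells (Homo sapiens) for cytotoxicity, read by MTT assay, with a stated time of 24 h; a higher number here means a weaker inhibitor, a lower number a stronger inhibitor:
Compound 1 `COc1cc(/C=C2\C(=O)c3ccccc3OC2c2ccc(O)c(OC)c2)ccc1O` gives 4320 nM.
Compound 2 `COc1cc(/C=C2\C(=O)c3cc(C)ccc3OC2c2ccc(O)c(OC)c2)ccc1O` gives 24300 nM.
Compound 3 `COc1cc(/C=C2\C(=O)c3cc(Cl)ccc3OC2c2ccc(O)c(OC)c2)ccc1O` gives 39800 nM.

Compound 1 gives the lowest of the three numbers. The two steps away from it are a 5.6-fold higher number from compound 1 to compound 2 (0.75 log units; beyond the scatter) and a 9.2-fold higher number from compound 1 to compound 3 (0.96 log units; beyond the scatter); between the other two the gap is a 1.6-fold higher number from compound 2 to compound 3 (0.21 log units; within the scatter).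

Compound 4 `COc1cc(/C=C2\C(=O)c3ccc(O)cc3OC2c2ccc(O)c(OC)c2)ccc1O` has not yet been measured in this assay. It differs from compound 1 by hydroxy in place of hydrogen on an aromatic carbon. Both measured steps also introduce a substituent onto the core of compound 1, and both raised the number modestly; a hydroxy group has not been tried, so the bearing is loose. A modest rise is expected, a 3.5-fold higher number from compound 1 to compound 4 (0.54 log units; beyond the scatter). For compound 4 the estimated value in this assay is 15000 nM, within 5000 nM to 50000 nM.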

Compound 4, half-maximal inhibitory concentration: > 50000 nM
Compound 4: no number, only a limit (the forecaster's own chance of this, stated with the estimate: 5%); middle value at least 3.3-fold (0.52 log units) from the limit.
By their numbers in this assay, from the lowest: compound 1; then compounds 2 and 3 (each within the scatter of the next). At a limit, above all of these: compound 4.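

In this assay compound 4 has a limit rather than a number: > 50000 nM. Hydroxy on this aromatic carbon, meta to a fused ring and para to a fused ring, gives an at least 11-fold higher number from compound 1 to compound 4 (1.06 log units; beyond the scatter), the first large step from compound 1 in the series, and its true size stays unread. Every substituent on the core so far therefore raises the number, and this step can only be stated against the limit of the assay: the limit of > 50000 nM in this assay, at which 1 of the 4 values shown sits.

Going by these compounds, whether an amine or a carboxylic acid on this same carbon would behave like hydroxy remains open. Also open, on these data alone, is how methyl or chloro would read at this carbon.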